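Swapping fluoro for chloro on the aryl ring: cytotoxicity outlook

This account rests on a few compounds, and the source may have more. Where it says the series, first, only, none or still open, it means among the compounds named here.

Measured so far:
Compound 1 `C[C@]1(CN2CCc3nc(-c4ccccc4F)ccc3C2)Cn2cc([N+](=O)[O-])nc2O1` — > 32 ug/mL
Compound 2 `C[C@]1(CN2CCc3nc(-c4cc(F)cc(F)c4)ccc3C2)Cn2cc([N+](=O)[O-])nc2O1` — > 32 ug/mL

In an ADME assay on Vero cells (Chlorocebus sabaeus) for cytotoxicity, read by MTT assay, with a stated time of 72 h (a lower number here means that less compound is tolerated, a higher number that more compound is tolerated), compound 1 reached only the upper limit of the test, so its value is a limit, not a number. In this assay compound 2 likewise gave only a limit. Among the compounds with values here, because of the limit of > 32 ug/mL in this assay, at which 2 of the 2 values shown sit, the single measured step, a step that the two limits leave unreadable from compound 1 to compound 2, cannot be read as a change in either direction; it tells only that both compounds were tolerated up to the highest concentration tested.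

Compound 3 `C[C@]1(CN2CCc3nc(-c4cc(F)cc(Cl)c4)ccc3C2)Cn2cc([N+](=O)[O-])nc2O1` differs from compound 2 by a single atom: chloro in place of fluoro on an aromatic carbon. Within the data shown here, nothing among the measured compounds speaks to what exchanging a fluoro for a chloro at this place does to tolerance by the cells, so the only guide is that the two neighbours of compound 3 both sat at the limit.

On that basis compound 3 is expected to behave much like compound 2, with an estimated step that the limit leaves unreadable from compound 2 to compound 3, which is no change beyond the scatter. The estimate for compound 3 in this assay is therefore 40 ug/mL, within a range from 20 ug/mL to 80 ug/mL, and most likely the assay will again report only a limit.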

Compound 3, half-maximal cytotoxic concentration: > 32 ug/mL
Compound 3 was reported as a limit; the forecaster's own chance of this, stated with the estimate: 75%; the middle value does not contradict the limit.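

Compound 3, like compound 1 and compound 2, gave only a limit in this assay, so no step among these three compounds can be read: the limit of > 32 ug/mL in this assay, at which 3 of the 3 values shown sit.

The compounds shown leave open at what concentration any of the three would start to harm the cells, and whether chloro in place of fluoro changes that concentration.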